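Working notes: chloro step from compound 2 to compound 3

The compounds below may be only part of what the source reports. "The series", "measured", "known", "first", "only" and "open" are said of these compounds alone.

Measured so far:
compound 1 `CC(C)[C@@H](O)C(=O)N1CCN(c2ccc3[nH]ncc3c2)CC1`, 3900 nM
compound 2 `O=C([C@H](O)c1ccccc1)N1CCN(c2ccc3[nH]ncc3c2)CC1`, 800 nM

Both numbers come from an assay on isolated protein for inhibition of Rho-associated protein kinase 2 (Homo sapiens); on this read-out higher numbers stand for weaker inhibition and lower numbers for stronger inhibition. Among the compounds with values here, compound 2 stands at the lower of the two; its only neighbour is compound 1, and the step of a 4.9-fold lower number from compound 1 to compound 2 (0.69 log units; beyond the scatter), a phenyl in place of isopropyl on the saturated chain carbon bound to the carbonyl carbon, separates them by more than the scatter.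

Compound 3 `O=C([C@H](O)c1cccc(Cl)c1)N1CCN(c2ccc3[nH]ncc3c2)CC1` is not yet measured. It differs from compound 2 by chloro in place of hydrogen on an aromatic carbon, on an aromatic carbon of the six-membered carbon-only ring, meta to a large group; cut one bond further out this reads phenyl to 3-chlorophenyl.

Within the data shown here, no measured step bears directly on this change: the one step in hand exchanges the whole group on the chain carbon and does not touch a substituent on the ring. With no comparison of this kind in the set, the expectation for compound 3 is a step of a 1.3-fold lower number from compound 2 to compound 3 (0.12 log units; within the scatter), of a size inside or near the scatter, with no direction that the present data support. The estimate for compound 3 is 600 nM, with a range from 250 nM to 1600 nM.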

Compound 3, half-maximal inhibitory concentration: 1000 nM
For compound 3 the middle estimate is 1.7-fold (0.22 log units) below the measured one, within the range that was stated.
By their numbers in this assay, from the lowest: compounds 2 and 3 (each within the scatter of the next); then compound 1.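

In this assay, chloro in place of hydrogen on an aromatic carbon, meta to a large group, gives a difference that stays within the scatter (a 1.3-fold higher number from compound 2 to compound 3 (0.10 log units; within the scatter)), so this first ring substituent neither clearly helps nor clearly harms, and compounds 2 and 3 cannot be ordered on this read-out. The advantage of the aromatic group over isopropyl remains with the chloro in place, since the comparison with the isopropyl compound still lies beyond the scatter (a 3.9-fold lower number from compound 1 to compound 3 (0.59 log units; beyond the scatter)), and this modest step is the only sign so far that a substituted phenyl on the chain carbon keeps that advantage. Nothing available gives a reason for the absence of a clear chloro effect at this position.

On these data alone, a single substituent at a single ring position says little about the ring as a whole, and whether a methoxy group, an aminomethyl group or a carboxylic acid on the same aromatic carbon would shift the number beyond the scatter remains open. As far as these compounds go, it also remains open how chloro would read on the other aromatic carbons of this ring.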